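The source may hold more compounds than are shown below. What is called first, only, known or untested is meant among the compounds shown, and "the series" means these compounds.

Compound 1 `Cc1oc2c3c(ccc2c(=O)c1C)OC[C@H]1[C@@H]3c2c(ccc(C(=O)Cc3ccccc3)c2O)OC1(C)C` carries a benzyl on its carbonyl carbon and a methyl on an aromatic carbon of the shared core. In a functional assay on HeLa cells (Homo sapiens) for cytotoxicity, read by MTT assay (on this read-out lower numbers stand for stronger inhibition and higher numbers for weaker inhibition), compound 1 reaches only a limit of the assay, > 100000 nM. Compound 2 `Cc1oc2c3c(ccc2c(=O)c1C)OC[C@H]1[C@@H]3c2c(ccc(C(=O)c3ccccc3)c2O)OC1(C)C` has a phenyl in place of that benzyl. In this assay compound 2 likewise reaches only a limit, > 100000 nM. Compound 3 `Cc1coc2c3c(ccc2c1=O)OC[C@H]1[C@@H]3c2c(ccc(C(=O)Cc3ccccc3)c2O)OC1(C)C` keeps the benzyl but carries hydrogen where compound 1 carries methyl. In this assay compound 3 again gives only a limit, > 100000 nM. Compound 3 therefore stands, with the other two, at the limit of > 100000 nM in this assay, at which 3 of the 3 values shown sit, and neither a step that the two limits leave unreadable from compound 1 to compound 2 nor a step that the two limits leave unreadable from compound 1 to compound 3 can be sized. Compound 4 `Cc1coc2c3c(ccc2c1=O)OC[C@H]1[C@@H]3c2c(ccc(C(=O)c3ccccc3)c2O)OC1(C)C` differs from compound 3 by phenyl in place of benzyl on a carbonyl carbon. The same exchange has been seen once, as a step that the two limits leave unreadable from compound 1 to compound 2, and both ends of it sat at the limit. For compound 4 the step that the limit leaves unreadable from compound 3 to compound 4 in this assay is therefore expected to be nothing beyond the scatter, with the limit itself the most likely outcome. Compound 4 is accordingly estimated at 150000 nM, within 60000 nM to 400000 nM, in this assay.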

Compound 4, half-maximal inhibitory concentration: 1500 nM
Estimate against measurement, compound 4: 100-fold (2.00 log units) above; measured number outside the range, below it.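

In this assay, going by these compounds alone, phenyl in place of benzyl on a carbonyl carbon now gives a readable result, an at least 66-fold lower number from compound 3 to compound 4 (1.82 log units; beyond the scatter), whereas the steps among the earlier compounds cannot be read. Hydrogen in place of methyl on an aromatic carbon likewise gives an at least 66-fold lower number from compound 2 to compound 4 (1.82 log units; beyond the scatter), so each exchange shows an effect here when the other is also present. Among these compounds, only compound 4, which carries both the phenyl and the hydrogen, comes off the limit, while compound 1, compound 2 and compound 3 stay on it: the limit of > 100000 nM in this assay, at which 3 of the 4 values shown sit.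

Going by these compounds, both steps remain bounds, so their true sizes stay open. On these data alone, it is also open whether a cyclohexyl or a pyridyl on the carbonyl carbon, or an ethyl in place of the hydrogen on the aromatic carbon, would keep the value of compound 4.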